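Phenyl in Place of Allyl on an Aromatic Nitrogen

The compounds below may be only part of what the source reports. "The series", "measured", "known", "first", "only" and "open" are said of these compounds alone.

Compound 1 `C=CCn1ccc(-c2cc(Br)ccc2OC)n1` and compound 2 `COc1ccc(Br)cc1-c1ccn(-c2ccccc2)n1` share one core; the difference between that core and the core of compound 3 `C=CCc1ccc(O)c(-c2ccn(CC=C)n2)c1` is not broken down here. In a functional assay on BV-2 cells (Mus musculus) for inhibition, read by Griess assay, with a stated time of 24 h (on this read-out higher numbers stand for weaker inhibition and lower numbers for stronger inhibition), compound 1 gives only a limit, > 200000 nM. Compound 2 likewise reaches only a limit in this assay, > 200000 nM. The step that the two limits leave unreadable from compound 1 to compound 2, the change (phenyl in place of allyl on an aromatic nitrogen), therefore cannot be sized, because both values sit at the limit of > 200000 nM in this assay, at which 2 of the 3 values shown sit. Among the compounds with values here, compound 3 gives 1200 nM in this assay, the only number among the three. Compound 4 `C=CCc1ccc(O)c(-c2ccn(-c3ccccc3)n2)c1` carries the same kind of change, (phenyl in place of allyl on an aromatic nitrogen), though here the ring atom two ring bonds away bears a large group rather than a group of 9 heavy atoms. With no readable precedent, compound 4 is expected near 2500 nM, from 600 nM to 15000 nM. This means an estimated step of a 2.1-fold higher number from compound 3 to compound 4 (0.32 log units; beyond the scatter), expected to stay within the usual scatter.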

Compound 4, half-maximal inhibitory concentration: 73000 nM
Compound 4: middle estimate off by 29-fold (1.47 log units), on the low side; measured number outside the range, above it.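

In this assay, phenyl in place of allyl on the aromatic nitrogen gives a 61-fold higher number from compound 3 to compound 4 (1.78 log units; beyond the scatter), so on this core the change costs a large part of the inhibition. Whether it does the same on the core of compound 1 stays unknown, and the step to compound 2 cannot be read because both values are limits: the limit of > 200000 nM in this assay, at which 2 of the 4 values shown sit A single readable step shows what the change does on one core only, and it does not establish that its size carries over to another core or explain why it is so large.

The compounds shown leave open how a benzyl group, a longer chain such as butyl, or a chain ending in an amine would read on that nitrogen. They also leave open whether any group there would match allyl on the core of compound 3.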